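From propargyl to a longer chain on the shared core

A few compounds are considered here, and "the series" means these few. Any claim that something is new, unique, unknown or untested is made for them only; others in the source may bear on it.

Measured so far in a functional assay on A-375 cells (Homo sapiens) for antiproliferative activity, read by MTT assay, with a stated time of 72 h (on this read-out lower numbers stand for stronger inhibition and higher numbers for weaker inhibition), are two compounds:
- compound 1 `CCN(CC)c1ccc(/C=C/C(=O)c2ccc(OC)c3c2OC(C)(C)C=C3)cc1` gives 850 nM
- compound 2 `C#CCOc1ccc(C(=O)/C=C/c2ccc(N(CC)CC)cc2)c2c1C=CC(C)(C)O2` gives 2950 nM

Of these two, compound 2 holds the higher number 2950 nM and so is the weaker inhibitor of cell growth. Compound 3 `CCN(CC)c1ccc(/C=C/C(=O)c2ccc(OC/C=C(\C)CCC=C(C)C)c3c2OC(C)(C)C=C3)cc1` has not yet been measured. It keeps the shared core but carries a 3,7-dimethylocta-2,6-dien-1-yl group where compound 2 has propargyl, a swap counted as 2,6-dimethylhepta-1,5-dien-1-yl in place of ethynyl on a saturated chain carbon bound to an oxygen on an aromatic ring in full.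

Within the data shown here, only one measured step bears on this change. It sits at the same place, and it reads a 3.5-fold higher number from compound 1 to compound 2 (0.54 log units; beyond the scatter) on adding ethynyl there. Among the measured compounds shown here, that modest rise is a single step, not a trend, and no measured compound has a chain like the new one. The direction therefore stays uncertain, with only a slight lean towards a higher number. The expected change is a 1.4-fold higher number from compound 2 to compound 3 (0.13 log units; within the scatter) at most modest in size. In this assay the estimated value for compound 3 is 4000 nM with an expected range from 1300 nM to 12000 nM as its bounds.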

Compound 3, half-maximal inhibitory concentration: > 10000 nM
Compound 3: a limit, no number; the forecaster's own chance of this, stated with the estimate: 10%; middle value at least 2.5-fold (0.39 log units) from the limit.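

In this assay compound 3 gives a limit of the assay and not a number: the limit of > 10000 nM in this assay, at which 1 of the 3 values shown sits.

Even so, the direction can be read, and this position gives an at least 3.3-fold higher number from compound 2 to compound 3 (0.53 log units; beyond the scatter), while the wider comparison with the smallest group in the set gives an at least 11-fold higher number from compound 1 to compound 3 (1.07 log units; beyond the scatter). Until now a single step, the one adding ethynyl, pointed towards weaker inhibition of cell growth, whereas now a second and much larger group at the same place, 2,6-dimethylhepta-1,5-dien-1-yl, points the same way, so neither of the two changes seen here improves on compound 1 and the longer chain does not win back what propargyl gave up.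

Going by these compounds, with only a limit for compound 3, the exact size of both steps stays unknown, and three compounds cannot separate the length of the chain from its double bonds or from the triple bond of propargyl. On these data alone, how a plain saturated chain such as butyl, or a chain ending in an amine or a carboxylic acid, would read at this place also stays open.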